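Methyl on the Ring Nitrogen: An Untested Change

The source may report more compounds than this note shows. Statements on the series, on what has been measured and on what is new or still open speak of the compounds shown alone.

Measured compounds:
compound 1, `COc1ccc(O)cc1OC[C@@H]1CCCN1`: 1080 nM
compound 2, `COc1ccccc1OC[C@@H]1CCCN1`: 53500 nM

Compound 2 gives the highest of the two numbers in an assay on cell membranes for displacement of a labelled ligand from Neuronal acetylcholine receptor; alpha4/beta2 (Rattus norvegicus), read by scintillation counting; on this read-out lower numbers stand for stronger inhibition and higher numbers for weaker inhibition. Going by the values given here, its nearest neighbour is compound 1, and the only measured step, a 50-fold higher number from compound 1 to compound 2 (1.69 log units; beyond the scatter), arose from hydrogen in place of hydroxy on an aromatic carbon, a large move toward weaker binding.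

Compound 3, `COc1ccccc1OC[C@@H]1CCCN1C`, has not been measured. It differs from compound 2 by methyl in place of hydrogen on an amine nitrogen in a ring. Among the compounds with values here, no measured step touches this ring nitrogen: the single known step concerns an aromatic carbon, so it says nothing about what a methyl on the amine nitrogen does here. Within the data shown here, with no bearing step, the expectation is a step no larger than the scatter, a 1.1-fold lower number from compound 2 to compound 3 (0.03 log units; within the scatter), starting from the value of compound 2, while the range is kept wide to reflect that nothing measured supports it. For compound 3 the estimated value in this assay is 50000 nM, expected to lie between 10000 nM and 200000 nM.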

Compound 3, inhibition constant: 9400 nM
Compound 3: the middle estimate sits 5.3-fold (0.73 log units) above what was measured, outside the stated range (below it).
By their numbers in this assay, from the lowest: compound 1; then compound 3; then compound 2.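

In this assay, going by these compounds alone, methyl in place of hydrogen on the amine nitrogen in the ring gives a 5.7-fold lower number from compound 2 to compound 3 (0.76 log units; beyond the scatter) and so shows that this position, which the earlier compounds left unchanged, does affect the measured binding. A second place on the shared core has now produced a step beyond the scatter, and this one runs toward stronger binding, whereas the step at the aromatic carbon, a 50-fold higher number from compound 1 to compound 2 (1.69 log units; beyond the scatter), runs toward weaker binding. Nothing at hand accounts for the gain from this single added carbon, so it stands as an observation about one pair of compounds and no more.

As far as these compounds go, this step comes from a single pair that lacks the hydroxy group of compound 1, so it remains open whether methyl on the ring nitrogen would shift the number in the same direction, or by a similar amount, with that hydroxy group in place. Also open, from the compounds shown here alone, is how the number would respond to an ethyl group, a longer chain or an acetyl group on the same nitrogen.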